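Trifluoromethyl for methyl on the benzyl group of compound 3

This account rests on a few compounds, and the source may have more. Where it says the series, first, only, none or still open, it means among the compounds named here.

Three compounds share one core. Compound 1 `CCN(Cc1cccc(F)c1)C(=O)C1CCN(S(=O)(=O)c2ccc3cn[nH]c3c2)CC1` gives 89% in a functional assay on CHO cells for positive allosteric modulation of muscarinic acetylcholine receptor M5 (Homo sapiens), read by calcium flux; a higher number here means a larger maximal response, a lower number a smaller maximal response. Compound 2 `CCN(Cc1cccc(Cl)c1)C(=O)C1CCN(S(=O)(=O)c2ccc3cn[nH]c3c2)CC1` gives 77% in that assay, and compound 3 `CCN(Cc1ccccc1C)C(=O)C1CCN(S(=O)(=O)c2ccc3cn[nH]c3c2)CC1` gives 103%. Compound 3 stands highest of the three: a number 14 percentage points higher from compound 1 to compound 3 (beyond the scatter) and a number 26 percentage points higher from compound 2 to compound 3 (beyond the scatter), both beyond the scatter, while a number 12 percentage points lower from compound 1 to compound 2 (beyond the scatter).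

Compound 4 `CCN(Cc1ccccc1C(F)(F)F)C(=O)C1CCN(S(=O)(=O)c2ccc3cn[nH]c3c2)CC1` has not yet been measured. It differs from compound 3 in one place: trifluoromethyl in place of methyl on an aromatic carbon. For the measured compounds named here, the only measured step that swaps one substituent for another on the same aromatic carbon is the one from compound 1 to compound 2, where the larger chloro in place of fluoro lowered the maximal response by a modest margin. The two other steps move the substituent and change its kind at once, so they bear less directly on this change. A modest step downward in that assay is therefore expected, with the estimate for compound 4 at 90%, ranging from 70% to 110%, which means an expected step of a number 13 percentage points lower from compound 3 to compound 4 (beyond the scatter).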

Compound 4, largest response reached (reported as percent of maximum), in percent of the reference or control that the assay uses: 92%
Estimate against measurement, compound 4: 2 percentage points below; the range from low to high includes it.
By their numbers in this assay, from the lowest: compound 2; then compounds 1 and 4 (each within the scatter of the next); then compound 3.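

In this assay, the first change shown on the aromatic carbon that carries the methyl of compound 3 gives a number 11 percentage points lower from compound 3 to compound 4 (beyond the scatter), so this position responds to trifluoromethyl in place of methyl. The 2-(trifluoromethyl)phenyl group also stands apart from 3-chlorophenyl, with a number 15 percentage points higher from compound 2 to compound 4 (beyond the scatter), but not from 3-fluorophenyl, with a number 3 percentage points higher from compound 1 to compound 4 (within the scatter). Nothing in the data available here accounts for the effect of this change.

The compounds shown leave open how methoxy or ethyl would fare on that same aromatic carbon, and so whether the response tracks any simple feature of the group placed there. They also leave open whether the standing of the 2-methylphenyl group would hold if a longer chain replaced the ethyl on the amide nitrogen.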